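A Second Methoxy on the Chalcone Aryl Ring

The source may report more compounds than this note shows. Statements on the series, on what has been measured and on what is new or still open speak of the compounds shown alone.

Compound 2 `COc1ccc(/C=C/C(=O)c2ccccc2NC(=O)NS(=O)(=O)c2ccc(C)cc2)cc1` gives 28.1 ug/mL in an ADME assay on the whole organism for cytotoxicity, with Artemia salina as the target, with a stated time of 24 h (on this read-out lower numbers stand for an effect already at smaller amounts and higher numbers for an effect only at larger amounts of compound), the higher of the two numbers measured, with compound 1 `Cc1ccc(S(=O)(=O)NC(=O)Nc2ccccc2C(=O)/C=C/c2ccccc2)cc1` close by at 25 ug/mL. Going by the values given here, the only step known so far, a 1.1-fold higher number from compound 1 to compound 2 (0.05 log units; within the scatter), came from a methoxy in place of hydrogen on an aromatic carbon. Compound 3 `COc1ccc(/C=C/C(=O)c2ccccc2NC(=O)NS(=O)(=O)c2ccc(C)cc2)c(OC)c1` differs from compound 2 by methoxy in place of hydrogen on an aromatic carbon. Since the earlier methoxy step stayed within the scatter, compound 3 is expected to show no change beyond the scatter, a 1.1-fold higher number from compound 2 to compound 3 (0.03 log units; within the scatter). Compound 3 is therefore estimated at 30 ug/mL, within 14 ug/mL to 65 ug/mL.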

Compound 3, concentration for half-maximal effect: 16 ug/mL
For compound 3 the middle estimate is 1.9-fold (0.27 log units) above the measured one, within the range that was stated.
By their numbers in this assay, from the lowest: compounds 3, 1 and 2 (each within the scatter of the next).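

In this assay, methoxy on the aromatic carbon ortho to a large group and meta to a methoxy group gives a 1.8-fold lower number from compound 2 to compound 3 (0.24 log units; within the scatter), so this position, like the earlier one, shows no change beyond the scatter. The full change from phenyl to 2,4-dimethoxyphenyl gives a 1.6-fold lower number from compound 1 to compound 3 (0.19 log units; within the scatter), so the two methoxy groups together also stay within it. No evidence at hand bears on this result. From the compounds shown here alone, it remains open whether this methoxy would read the same without the other methoxy on the ring. An amine or a carboxylic acid at this position could still move the number beyond the scatter.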